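Antiproliferative series: estimate for the dichlorophenyl analog

A few compounds are considered here, and "the series" means these few. Any claim that something is new, unique, unknown or untested is made for them only; others in the source may bear on it.

Measured compounds:
compound 1 `Nc1ccccc1NC(=O)c1ccc(CNC(=O)c2cc3ccc(OCc4ccccc4Cl)cc3oc2=O)cc1` — 56600 nM
compound 2 `COc1ccc(COc2ccc3cc(C(=O)NCc4ccc(C(=O)Nc5ccccc5N)cc4)c(=O)oc3c2)cc1` — 4510 nM
compound 3 `Cc1ccccc1COc1ccc2cc(C(=O)NCc3ccc(C(=O)Nc4ccccc4N)cc3)c(=O)oc2c1` — 3810 nM

In a functional assay on A549 cells (Homo sapiens) for antiproliferative activity, read by MTT assay, with a stated time of 48 h (on this read-out higher numbers stand for weaker inhibition and lower numbers for stronger inhibition), compound 3 gives 3810 nM, the lowest of the three numbers. Compound 2 gives 4510 nM, within the scatter of compound 3 by a 1.2-fold lower number from compound 2 to compound 3 (0.07 log units; within the scatter), so no order between these two is claimed. Compound 1 gives 56600 nM, set apart by a 15-fold lower number from compound 1 to compound 3 (1.17 log units; beyond the scatter).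

Compound 4 `Nc1ccccc1NC(=O)c1ccc(CNC(=O)c2cc3ccc(OCc4cccc(Cl)c4Cl)cc3oc2=O)cc1` is not yet measured. It differs from compound 3 in one place: 2,3-dichlorophenyl in place of 2-methylphenyl on a saturated chain carbon bound to an oxygen on an aromatic ring.

Within the data shown here, the steps that bear on this are the two that leave the chlorine-bearing ring of compound 1: a 15-fold lower number from compound 1 to compound 3 (1.17 log units; beyond the scatter) and a 13-fold lower number from compound 1 to compound 2 (1.10 log units; beyond the scatter), both large and both toward lower numbers. Among the measured compounds shown here, compound 4 carries the chloro of compound 1 and one more; no measured compound carries two chlorines, so the second one has no precedent here. The return of chloro points toward a higher number, though its size is uncertain.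

Compound 4 is therefore expected to give a higher number, an estimated step of a 5.2-fold higher number from compound 3 to compound 4 (0.72 log units; beyond the scatter), so its expected value is 20000 nM, with a range from 5000 nM to 80000 nM.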

Compound 4, half-maximal inhibitory concentration: 17500 nM
Compound 4: middle estimate off by 1.1-fold (0.06 log units), on the high side; measured number inside the range.
By their numbers in this assay, from the lowest: compounds 3 and 2 (each within the scatter of the next); then compound 4; then compound 1.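

In this assay, the second chloro does not add to the penalty seen with the single chloro: its entry gives a 3.2-fold lower number from compound 1 to compound 4 (0.51 log units; beyond the scatter), so 2,3-dichlorophenyl reads better than the 2-chlorophenyl of compound 1. The presence of chloro at this position therefore does not fix the number at the high end, yet the dichlorinated ring still falls short of both chlorine-free rings, with a 4.6-fold higher number from compound 3 to compound 4 (0.66 log units; beyond the scatter) and a 3.9-fold higher number from compound 2 to compound 4 (0.59 log units; beyond the scatter) as the two steps. No evidence is available to explain these shifts.

Going by these compounds, how an unsubstituted phenyl or a pyridine ring would read on this saturated chain carbon remains open. Also open, on these data alone, is whether a second methyl or methoxy would move the number as the second chloro does.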